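The source may hold more compounds than are shown below. What is called first, only, known or untested is meant among the compounds shown, and "the series" means these compounds.

Of the compounds shown here, three have been tested so far in a functional assay on A549 cells (Homo sapiens) for antiproliferative activity, read by MTT assay, with a stated time of 72 h (on this read-out lower numbers stand for stronger inhibition and higher numbers for weaker inhibition), and none has given a number. Compound 1 `O=C1Nc2c(F)cccc2/C1=C1/Nc2ccccc2C1=O` returned > 100000 nM, which is a limit of the assay. Compound 2 `O=C1Nc2c(Cl)cccc2/C1=C1/Nc2ccccc2C1=O` returned > 100000 nM, also a limit. Going by these compounds, compound 3 `O=C1Nc2ccccc2/C1=C1/Cc2ccccc2C1=O` returned > 100000 nM, again only a limit, so its place on the scale stays open.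

Compound 4 `O=C1Nc2ccc(Br)cc2/C1=C1/Cc2ccccc2C1=O` differs from compound 3 by a single change, bromo in place of hydrogen on an aromatic carbon. Going by the values given here, the only measured step that offers any guidance is a step that the two limits leave unreadable from compound 1 to compound 2. It swaps one halogen for another and has no readable size, so it gives no figure to carry over. The broader picture is the limit of > 100000 nM in this assay, at which 3 of the 3 values shown sit. Nothing here points to a large gain in this assay, so only a small step of uncertain direction is expected. The estimated step is an at least 1.2-fold lower number from compound 3 to compound 4 (0.09 log units; that floor lies within the scatter). Compound 4 is expected near 80000 nM, with an estimated range of 20000 nM to 150000 nM, and it may well return only a limit.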

Compound 4, half-maximal inhibitory concentration: > 100000 nM
Compound 4 gave a limit, no number; the forecaster's own chance of this, stated with the estimate: 65%; middle value at least 1.2-fold (0.09 log units) away from the limit.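

Compound 4, like compound 3, gave only a limit in this assay, so the step from compound 3 to compound 4 cannot be read. The compounds shown leave open where any of them truly stands, and whether any change to the shared core gives a readable number: the limit of > 100000 nM in this assay, at which 4 of the 4 values shown sit.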